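A few compounds are considered here, and "the series" means these few. Any claim that something is new, unique, unknown or untested is made for them only; others in the source may bear on it.

Compound 1, `CC(=O)N[C@@H](CSC(=O)Nc1ccc(I)cc1)C(=O)O`: in a functional assay on GC3/C1 cells (Homo sapiens) for cytotoxicity, read by MTT assay, with a stated time of 6 days (a higher number here means a weaker inhibitor, a lower number a stronger inhibitor), compound 1 reaches only the assay limit > 200000 nM.
Compound 2, `COc1ccccc1NC(=O)SC[C@H](NC(C)=O)C(=O)O`: in this assay compound 2 likewise reaches only the limit > 200000 nM.
Compound 3, `CC(=O)N[C@@H](CSC(=O)Nc1ccc(Cl)cc1)C(=O)O`: in this assay compound 3 gives 8130 nM.

Within the data shown here, compound 3 thus holds the only numerical value in the set; the other two results are limits. Compound 4, `CC(=O)N[C@@H](CSC(=O)Nc1ccc(Br)cc1)C(=O)O`, is not yet measured. Its change from compound 3: bromo in place of chloro on an aromatic carbon. Among the measured compounds shown here, the one measured step of this kind is an at least 24-fold lower number from compound 1 to compound 3 (1.39 log units; beyond the scatter), a halogen exchange at the same place. The move to compound 4 runs back toward the iodo of compound 1, so a weakening is expected, probably smaller than that step; given (the limit of > 200000 nM in this assay, at which 2 of the 3 values shown sit), a limit result for compound 4 cannot be excluded. For compound 4 the expected value in this assay is 30000 nM, range 6000 nM to 150000 nM, the expected step being a 3.7-fold higher number from compound 3 to compound 4 (0.57 log units; beyond the scatter).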

Compound 4, half-maximal inhibitory concentration in the GC3/C1 assay: 63500 nM
Compound 4: the middle estimate sits 2.1-fold (0.33 log units) below what was measured, within the range that was stated.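

In the GC3/C1 assay the three halogens at this place now separate, with a 7.8-fold higher number from compound 3 to compound 4 (0.89 log units; beyond the scatter) and an at least 3.1-fold lower number from compound 1 to compound 4 (0.49 log units; beyond the scatter), the latter resting on a limit for compound 1. In a physicochemical assay for solubility (on this read-out lower numbers stand for lower solubility and higher numbers for higher solubility), compound 3 gives 721 ug/mL and compound 4 gives 50 ug/mL. Of this pair, compound 3 therefore holds the better result on both read-outs, so chloro remains the preferred halogen among those compared.

One pair cannot tell whether the two read-outs move together. From the compounds shown here alone, how fluoro or an amine at this place would read stays open.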